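Fluoro Addition on the Central Aryl Ether Ring

A few compounds are considered here, and "the series" means these few. Any claim that something is new, unique, unknown or untested is made for them only; others in the source may bear on it.

Measured so far:
- compound 1 `O=C(Nc1ccc(Oc2ccnc3[nH]ccc23)cc1)c1cc2cccnc2n(-c2ccc(Br)cc2)c1=O`: "not determined" (no result reported)
- compound 2 `O=C(Nc1ccc(Oc2ccnc3[nH]ccc23)cc1)c1cc2cccnc2n(-c2ccc(F)c(Cl)c2)c1=O`: "not determined" (no result reported)
- compound 3 `O=C(Nc1ccc(Oc2ccnc3[nH]ccc23)cc1)c1cc2cccnc2n(-c2ccc(C(F)(F)F)cc2Cl)c1=O`: 1950 nM

Compound 1 has no single number in a functional assay on NCI-H460 cells (Homo sapiens) for antiproliferative activity, read by MTT assay, with a stated time of 72 h; a lower number here means a stronger inhibitor, a higher number a weaker inhibitor; one further entry, compound 2, is likewise without a number. The only figure in this assay comes from compound 3, which gives 1950 nM.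

Compound 4 `O=C(Nc1ccc(Oc2ccnc3[nH]ccc23)c(F)c1)c1cc2cccnc2n(-c2ccc(Br)cc2)c1=O` differs from compound 1 by fluoro in place of hydrogen on an aromatic carbon. Going by the values given here, with no step between measured compounds in this assay, no direction can be drawn from the numbers, and the expectation for this change is a step no larger than the scatter.

For compound 4 the estimate in this assay is 1500 nM, with a range from 300 nM to 8000 nM, anchored only on the value of compound 3.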

Compound 4, half-maximal inhibitory concentration: 260 nM
Estimate against measurement, compound 4: 5.8-fold (0.76 log units) above, and the stated range ends above it.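

Compound 4 has a single number in this assay and compound 1 has none, so no step can be read between them. Going by these compounds, what fluoro in place of hydrogen does to activity in this assay stays open. No evidence bears on this result.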